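The source may report more compounds than this note shows. Statements on the series, on what has been measured and on what is new or still open speak of the compounds shown alone.

Two compounds share one core. Compound 1 is `Cc1nc(-c2cccnc2)sc1-c1nnc(Cc2ccccc2)o1`, and compound 2 is `Cc1nc(-c2cccnc2)sc1-c1nnc(-c2ccccc2Cl)o1`. In an ADME assay on HeLa cells (Homo sapiens) for cytotoxicity, read by MTT assay (a lower number here means that less compound is tolerated, a higher number that more compound is tolerated), compound 1 gives > 100 ug/mL, which is a limit of the assay rather than a number. Compound 2 gives > 100 ug/mL in this assay, again a limit. Because both sit at the limit of > 100 ug/mL in this assay, at which 2 of the 2 values shown sit, the step that the two limits leave unreadable from compound 1 to compound 2 cannot be read in size or direction; all that can be said of compound 2 is that it is tolerated at least up to that limit.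

Compound 3 is `COc1ccccc1-c1nnc(-c2sc(-c3cccnc3)nc2C)o1`. It differs from compound 2 by methoxy in place of chloro on an aromatic carbon. Going by the values given here, no measured step bears on this change, since the only step between measured compounds is unreadable. The expectation is therefore that compound 3 also reaches the limit in this assay, with no step beyond the scatter. Compound 3 is expected to give 150 ug/mL, with a range from 60 ug/mL to 400 ug/mL. That estimate means an expected step that the limit leaves unreadable from compound 2 to compound 3.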

Compound 3, half-maximal cytotoxic concentration: > 100 ug/mL
Compound 3: a limit, no number; the forecaster's own chance of this, stated with the estimate: 85%; the middle value does not contradict the limit.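

In this assay compound 3 gives > 100 ug/mL, a limit and not a number. Its steps from compound 1 and compound 2 therefore cannot be read: the limit of > 100 ug/mL in this assay, at which 3 of the 3 values shown sit.

The compounds shown leave open at what concentration any of them becomes toxic to these cells, and whether benzyl, 2-chlorophenyl and 2-methoxyphenyl differ at all.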